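Rat microsomal half-life: compound 1 and its thiazolidinedione analogue

This account rests on a few compounds, and the source may have more. Where it says the series, first, only, none or still open, it means among the compounds named here.

Compound 1 `CC(C)[C@H](C[C@H]1OC(=O)NC1=O)c1ccc(-c2ccc3cccc(F)c3c2)[nH]c1=O` gives 0.95 h in an ADME assay on microsomes from liver (Rattus norvegicus) for metabolic stability; a higher number here means that the compound lasts longer, a lower number that the compound disappears faster.
Compound 2 `CCC(/C=C1\OC(=O)NC1=O)(CC)c1ccc(-c2ccc3cc(F)cc(F)c3c2)[nH]c1=O` in this assay reaches > 3 h, a limit rather than a number.
Compound 3 `O=C1NC(=O)/C(=C/C(c2ccc(-c3ccc4cccc(F)c4c3)[nH]c2=O)C2CCCC2)O1` in this assay reaches > 3 h, also a limit rather than a number.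

Going by the values given here, compound 1 holds the only plain number here; the other two values sit at the limit of > 3 h in this assay, at which 2 of the 3 values shown sit. Compound 4 `CC(C)[C@H](C[C@H]1SC(=O)NC1=O)c1ccc(-c2ccc3cccc(F)c3c2)[nH]c1=O` differs from compound 1 by 2,4-dioxo-1,3-thiazolidin-5-yl in place of 2,4-dioxo-1,3-oxazolidin-5-yl on a saturated chain carbon, two bonds along the chain from an aromatic carbon. Among the compounds with values here, no step between measured compounds matches this change, so nothing here fixes its size or direction; with two of three compounds at the limit, a rise in this assay beyond the scatter is possible but unsupported, and a step within the scatter is expected. Compound 4 is accordingly estimated at 1.3 h, from 0.6 h to 3 h, with the step of a 1.4-fold higher number from compound 1 to compound 4 (0.14 log units; within the scatter) expected.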

Compound 4, half-life in the Rattus norvegicus assay: 0.143 h
Beside the measured number, compound 4's estimate is 9.1-fold (0.96 log units) above it; the measured number lies below the stated range.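

In the Rattus norvegicus assay the exchange at this saturated chain carbon is far from neutral: 2,4-dioxo-1,3-thiazolidin-5-yl in place of 2,4-dioxo-1,3-oxazolidin-5-yl gives a 6.6-fold lower number from compound 1 to compound 4 (0.82 log units; beyond the scatter), the only step shown for this change. In a physicochemical assay for solubility, in phosphate buffer, measured as kinetic solubility (a lower number here means a less soluble compound, a higher number a more soluble compound), compound 1 gives 35400 nM and compound 4 gives 31200 nM, two values within the scatter of each other. Nothing measured here accounts for the step in half-life.

Going by these compounds, it remains open how a carboxylic acid at this place would fare in the Rattus norvegicus assay. On these data alone, whether the same step holds for the exchange in compound 2 or compound 3 also stays open.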